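The source may report more compounds than this note shows. Statements on the series, on what has been measured and on what is new or still open speak of the compounds shown alone.

Compound 1 `CCCOC(=O)C1=C(C)NC(=S)NC1c1ccoc1` gives 4% in an assay on membranes from CHO cells for displacement of a labelled ligand from adenosine receptor A1 (Homo sapiens), read by scintillation counting, with a stated time of 60 min, tested at 1 uM (on this read-out lower numbers stand for less inhibition and higher numbers for more inhibition at the one concentration tested (going by the name of the read-out)), the lowest of the three numbers recorded in this assay. Compound 2 `CC1=C(C(=O)OC(C)(C)C)C(c2ccoc2)NC(=S)N1` gives 18%, and compound 3 `CC1=C(C(=O)OCc2ccccc2)C(c2ccoc2)NC(=S)N1` gives 25%; both sit above compound 1, by a number 14 percentage points higher from compound 1 to compound 2 (beyond the scatter) and a number 21 percentage points higher from compound 1 to compound 3 (beyond the scatter), while compound 2 and compound 3 differ by a number 7 percentage points higher from compound 2 to compound 3 (within the scatter). Compound 4 `CCCOC(=O)C1=C(C)NC(=S)NC1c1cccs1` keeps the ester of compound 1 and changes the ring on the saturated ring carbon: thiophen-2-yl in place of furan-3-yl on a saturated ring carbon. Among the compounds with values here, none of the measured steps touch this position; all three concern the ester. With nothing bearing on the change, no step beyond the scatter is expected, and compound 4 is estimated at 8%, between 0% and 22%, a step of a number 4 percentage points higher from compound 1 to compound 4 (within the scatter) that is expected to stay within the scatter.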

Compound 4, a percentage reported as inhibition, at one concentration (the size of the read-out at that concentration, not a potency): 7%
For compound 4 the middle estimate is 1 percentage points above the measured one; the range from low to high includes it.
By their numbers in this assay, from the lowest: compounds 1 and 4 (each within the scatter of the next); then compounds 2 and 3 (each within the scatter of the next).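

In this assay, within the data shown here, the first change at this position, thiophen-2-yl in place of furan-3-yl on a saturated ring carbon, gives a number 3 percentage points higher from compound 1 to compound 4 (within the scatter). With the propoxycarbonyl group kept, these two five-membered aromatic rings cannot be told apart on this read-out. Nothing available explains this result. Still open, on these data alone, is whether a phenyl ring or a ring carrying an amine or a carboxylic acid at this carbon would separate from furan-3-yl. Also open, as far as these compounds go, is whether thiophen-2-yl and furan-3-yl stay equivalent alongside the benzyl or tert-butyl esters.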